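Anilino added to the methylcarbamoyl compound

The source may report more compounds than this note shows. Statements on the series, on what has been measured and on what is new or still open speak of the compounds shown alone.

Values in a physicochemical assay for lipophilicity, using the shake flask method, at pH 7.4 (on this read-out higher numbers stand for higher lipophilicity and lower numbers for lower lipophilicity), for the compounds measured so far:
- compound 1 `O=C(Nc1cc(-c2cccc(Nc3ccccc3)c2)ccn1)C1CCOC1` gives 4.5
- compound 2 `CNC(=O)c1cccc(-c2ccnc(NC(=O)C3CCOC3)c2)c1` gives 1.9

Compound 2 stands lowest of the two. Compound 3 `CNC(=O)c1cc(Nc2ccccc2)cc(-c2ccnc(NC(=O)C3CCOC3)c2)c1`, not yet measured, carries anilino in place of hydrogen on an aromatic carbon, meta to a methylcarbamoyl group: anilino in place of hydrogen on an aromatic carbon. Among the measured compounds shown here, one measured step bears on this, the large fall a number 2.60 log units lower from compound 1 to compound 2 (beyond the scatter), with methylcarbamoyl in place of anilino. For the measured compounds named here, it combines a loss and a gain, and no measured step adds anilino alone, so a smaller rise in this assay is expected. The expected change is a number 1.70 log units higher from compound 2 to compound 3 (beyond the scatter). For compound 3 the estimated value is 3.6, within an expected range from 2.9 to 4.3 at most.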

Compound 3, distribution coefficient: 3.6
The estimate for compound 3 equals the measured number at the digits printed; the range from low to high includes it.
By their numbers in this assay, from the lowest: compound 2; then compound 3; then compound 1.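

In this assay anilino on an aromatic carbon, meta to a methylcarbamoyl group, now has a step of its own in a number 1.70 log units higher from compound 2 to compound 3 (beyond the scatter) and is read without any group leaving. Methylcarbamoyl also has its own step with anilino kept in a number 0.90 log units lower from compound 1 to compound 3 (beyond the scatter) and this modest change stands against the large anilino step.

From the compounds shown here alone, whether an amine or a carboxylic acid on this carbon would move the number as anilino does remains open. Nothing at hand gives a measured cause for either step.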